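The source may hold more compounds than are shown below. What is called first, only, known or untested is meant among the compounds shown, and "the series" means these compounds.

Compound 3 `Cc1c(-c2nc3c(-c4ccc5c(c4)CCC[C@H]5NC(=O)c4nc(C(C)(C)C)no4)ccnc3[nH]2)cnn1C1CCOCC1` holds the highest of the three numbers measured in an ADME assay on Caco-2 cells (Homo sapiens) for permeability, in the apical to basolateral direction; on this read-out higher numbers stand for higher permeability and lower numbers for lower permeability: compound 3 gives 5 10^-6 cm/s. Compound 1 `Cn1cc(-c2nc3c(-c4ccc(CNC(=O)c5cc(C(C)(C)C)no5)c(F)c4)ccnc3[nH]2)cn1` gives 3 10^-6 cm/s, within the scatter of compound 3. Compound 2 `Cn1cc(-c2nc3c(-c4ccc5c(c4)CCC[C@H]5NC(=O)c4nc(C(C)(C)C)no4)ccnc3[nH]2)cn1` gives 1 10^-6 cm/s, the furthest from compound 3; the step is a 5.0-fold higher number from compound 2 to compound 3 (0.70 log units; beyond the scatter). Compound 4 `Cc1nn(C(C)C)c(C)c1-c1nc2c(-c3ccc4c(c3)CCC[C@H]4NC(=O)c3nc(C(C)(C)C)no3)ccnc2[nH]1` differs from compound 3 in one place: a group of 10 heavy atoms (8 carbon, 2 nitrogen; one five-membered aromatic ring with 2 hetero atoms) in place of a group of 12 heavy atoms (9 carbon, 2 nitrogen, 1 oxygen; one five-membered aromatic ring with 2 hetero atoms, one six-membered non-aromatic ring with 1 hetero atom), on an aromatic carbon. Among the measured compounds shown here, the only measured step at this position is that from compound 2 to compound 3, and the group that entered there is the group that leaves here, so it bears only loosely; nothing measured covers the entering group. No step beyond the scatter is therefore expected in this assay, with a lean toward a slightly higher number. For compound 4 the estimate is 6 10^-6 cm/s, between 3 10^-6 cm/s and 12 10^-6 cm/s, an expected step of a 1.2-fold higher number from compound 3 to compound 4 (0.08 log units; within the scatter).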

Compound 4, apparent permeability in the Caco-2 assay: 3.4 10^-6 cm/s
Beside the measured number, compound 4's estimate is 1.8-fold (0.25 log units) above it; low and high end bracket the measured number.
By their numbers in the Caco-2 assay, from the lowest: compound 2; then compounds 1, 4 and 3 (each within the scatter of the next).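

In the Caco-2 assay, a second group at this position also stands clear of the smaller group of compound 2, with a 3.4-fold higher number from compound 2 to compound 4 (0.53 log units; beyond the scatter), so the six-membered non-aromatic ring with 1 hetero atom is not required for that gain. Removing this ring does not separate the two larger groups, with a 1.5-fold lower number from compound 3 to compound 4 (0.17 log units; within the scatter). In a physicochemical assay for solubility, in simulated intestinal fluid (on this read-out higher numbers stand for higher solubility and lower numbers for lower solubility), however, compound 3 gives 7 ug/mL and compound 4 gives 56 ug/mL, and the same change does separate them: the measured solubility of compound 3, 7 ug/mL, and of compound 4, 56 ug/mL, an 8.0-fold higher number (0.90 log units; beyond the scatter).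

Which part of the change carries the solubility step stays open. So do permeability and solubility with an amine or a carboxylic acid at this position.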